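Adding a Methoxy to the Ethyl Chain of Compound 1

This account rests on a few compounds, and the source may have more. Where it says the series, first, only, none or still open, it means among the compounds named here.

Measured compounds:
compound 1, `CCc1nc2nc(C)cc(Nc3ccc(C(F)(F)F)cc3)n2n1`, 39000 nM
compound 2, `Cc1cc(Nc2ccc(S(F)(F)(F)(F)F)cc2)n2nc(C(C)(F)F)nc2n1`, 30000 nM
compound 3, `CCc1nc2nc(C)cc(Nc3ccc(Cl)cc3)n2n1`, 170000 nM

Of the compounds shown here, three on a shared core have been measured in a physicochemical assay for solubility, at pH 6.5; a lower number here means a less soluble compound, a higher number a more soluble compound. Compound 1 gives 39000 nM, the second highest of the three numbers. Compound 2 gives 30000 nM, a number within the scatter of compound 1, so the two cannot be ordered. Within the data shown here, compound 3 gives 170000 nM, and the one measured single-point step is a 4.4-fold higher number from compound 1 to compound 3 (0.64 log units; beyond the scatter).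

Compound 4, `COCCc1nc2nc(C)cc(Nc3ccc(C(F)(F)F)cc3)n2n1`, is not yet measured. It differs from compound 1 by methoxy in place of hydrogen on a saturated chain carbon, two bonds along the chain from an aromatic carbon. Among the measured compounds shown here, no measured step touches this chain; the step from compound 1 to compound 3 concerns the group on the aromatic ring and does not bear on the change in compound 4. For the measured compounds named here, with no step to lean on, only a small movement in this assay is expected, most likely within the scatter, leaning upward. Compound 4 is therefore estimated at 55000 nM, between 25000 nM and 120000 nM, an expected step of a 1.4-fold higher number from compound 1 to compound 4 (0.15 log units; within the scatter).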

Compound 4, solubility: 71000 nM
Estimate against measurement, compound 4: 1.3-fold (0.11 log units) below; the measured number falls inside the stated range.
By their numbers in this assay, from the lowest: compounds 2, 1 and 4 (each within the scatter of the next, the first and the last beyond it); then compound 3.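

Among these compounds, compound 4 gives the first reading on the ethyl chain of compound 1, since the earlier step concerned only the group on the aromatic ring. In this assay, methoxy in place of hydrogen on a saturated chain carbon, two bonds along the chain from an aromatic carbon, gives a 1.8-fold higher number from compound 1 to compound 4 (0.26 log units; within the scatter) and so cannot be told from repeat measurement; compound 1 and compound 4 cannot be ordered. Nothing shown accounts for this result.

The compounds shown leave open whether an amine, a carboxylic acid or a longer chain at the same place would give a step beyond the scatter. They also leave open whether ethyl to 2-methoxyethyl would give a step of similar size on compound 3, which carries chloro in place of trifluoromethyl.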